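This account rests on a few compounds, and the source may have more. Where it says the series, first, only, none or still open, it means among the compounds named here.

Three compounds of the shared core have numbers in an assay on isolated protein for inhibition of aldehyde dehydrogenase 1A1 (Homo sapiens), read by spectrophotometry, tested at 10 uM; a higher number here means more inhibition at the concentration tested (going by the name of the read-out), a lower number less inhibition. Compound 1 `Cc1cccc(Cn2c(CN3CCN(C(=O)c4ccc([N+](=O)[O-])cc4)CC3)nc3ccccc32)c1` gives 24.3%. Compound 2 `O=C(C1CC1)N1CCN(Cc2nc3ccccc3n2Cc2ccccc2F)CC1` gives 40.7%. Compound 3 `Cc1cccc(Cn2c(CN3CCN(C(=O)c4cccs4)CC3)nc3ccccc32)c1` gives 60.8%. Compound 2 thus stands second highest of the three, with compound 1 below it and compound 3 above it, both gaps beyond the scatter.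

Among the compounds with values here, the one step measured so far, a number 36.5 percentage points higher from compound 1 to compound 3 (beyond the scatter), changes the group on the carbonyl carbon and leaves the rest untouched.

Compound 4 `CC(C)CCn1c(CN2CCN(C(=O)C3CC3)CC2)nc2ccccc21` differs from compound 2 at a different place: isobutyl in place of 2-fluorophenyl on a saturated chain carbon bound to an aromatic nitrogen. Within the data shown here, no measured step varies this position, so the step from compound 1 to compound 3 does not bear on it, and the measured compounds give no direction for such a change. The expectation is therefore no step beyond the scatter, and compound 4 is estimated in this assay at 40%, within 20% to 60%, which means an expected step of a number 0.7 percentage points lower from compound 2 to compound 4 (within the scatter).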

Compound 4, a percentage reported as inhibition, at one concentration (the size of the read-out at that concentration, not a potency): 70%
Estimate against measurement, compound 4: 30 percentage points below; measured number outside the range, above it.
By their numbers in this assay, from the lowest: compound 1; then compound 2; then compounds 3 and 4 (each within the scatter of the next).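

In this assay, within the data shown here, the group on the saturated chain carbon bound to an aromatic nitrogen can clearly shift the read-out, which no earlier step showed: the change gives a number 29.3 percentage points higher from compound 2 to compound 4 (beyond the scatter) with isobutyl in place of 2-fluorophenyl. At this position and with this carbonyl group, an aromatic ring is therefore not needed for inhibition at the concentration tested, since the smaller group without a ring carries the higher number. Nothing at hand explains this step.

From the compounds shown here alone, it remains open how much of the step follows from losing the fluorine and how much from losing the ring, which an unsubstituted benzyl group in place of 2-fluorobenzyl would help to separate. Also open, going by these compounds, are whether a longer chain or a chain ending in an amine continues the trend, and whether isopentyl gives a similar step alongside thiophen-2-yl on the carbonyl.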